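The source may report more compounds than this note shows. Statements on the series, on what has been measured and on what is new or still open speak of the compounds shown alone.

Working notes on the series. The shared core is that of compound 2 `O=C(Nc1cccc(CNc2nccnc2Cl)c1)Nc1ccc(Cl)cc1Br`, with a variable aryl group on the amide-type nitrogen. In a functional assay on HepG2 cells (Homo sapiens) for antiproliferative activity, read by MTT assay, with a stated time of 48 h (on this read-out higher numbers stand for weaker inhibition and lower numbers for stronger inhibition), compound 2 gives 6720 nM. Compound 3 `Cc1ccc(NC(=O)Nc2cccc(CNc3nccnc3Cl)c2)c(C)c1` gives 9290 nM in this assay, and its gap to compound 2 lies within the scatter. Compound 1 `O=C(Nc1cccc(CNc2nccnc2Cl)c1)Nc1cccc2ccccc12` reaches only the limit of this assay, > 40000 nM. Compound 2 thus stands at one of the two numbers reported, with compound 3 beside it, and one further compound sits at a limit, namely (the limit of > 40000 nM in this assay, at which 1 of the 3 values shown sits). Going by the values given here, the single step with a number at each end is a 1.4-fold higher number from compound 2 to compound 3 (0.14 log units; within the scatter), a change of the aryl group that moved nothing beyond the scatter.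

Compound 4 `COc1ccc(NC(=O)Nc2cccc(CNc3nccnc3Cl)c2)cc1` differs from compound 2 in one place: 4-methoxyphenyl in place of 2-bromo-4-chlorophenyl on an amide-type nitrogen. This step bears most resemblance to the measured one, which was within the scatter, while compound 1 shows only a limit. The expected step is therefore small, a 1.8-fold higher number from compound 2 to compound 4 (0.25 log units; within the scatter), toward a higher number. For compound 4 the expected value in this assay is 12000 nM, with a range of 5000 nM to 35000 nM.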

Compound 4, half-maximal inhibitory concentration: 12000 nM
Beside the measured number, compound 4's estimate shows no gap at the digits printed; measured number inside the range.
By their numbers in this assay, from the lowest: compounds 2, 3 and 4 (each within the scatter of the next). At a limit, above all of these: compound 1.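

Compound 4 replaces the 2-bromo-4-chlorophenyl group with 4-methoxyphenyl on the same amide-type nitrogen, adding a hydrogen-bond acceptor where the group it replaces counts none, and in this assay the step reads a 1.8-fold higher number from compound 2 to compound 4 (0.25 log units; within the scatter). Set against the 2,4-dimethylphenyl group, the same 4-methoxyphenyl group gives a 1.3-fold higher number from compound 3 to compound 4 (0.11 log units; within the scatter). The two halogens, the two methyl groups and the methoxy group on this aryl ring therefore give numbers that cannot be separated, while compound 1 stays apart as a limit and not a number: the limit of > 40000 nM in this assay, at which 1 of the 4 values shown sits.

The compounds shown leave open whether an amine or a carboxylic acid on this aryl ring would move the number beyond the scatter. They also give no order among compounds 2, 3 and 4.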